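A Hydroxymethyl on the Amine Ring of Compound 3

A few compounds are considered here, and "the series" means these few. Any claim that something is new, unique, unknown or untested is made for them only; others in the source may bear on it.

Three compounds share one core and differ only in the group on the saturated chain carbon bound to a double-bonded chain carbon. Compound 1 `CCC/C=C/C(=O)Nc1cc2c(N3CCCc4ccccc43)ncnc2cc1O[C@@H]1CCOC1` gives 11800 nM in a functional assay on PC-3 cells (Homo sapiens) for antiproliferative activity, read by MTT assay, with a stated time of 72 h; on this read-out lower numbers stand for stronger inhibition and higher numbers for weaker inhibition. Compound 2 `CN(C)C/C=C/C(=O)Nc1cc2c(N3CCCc4ccccc43)ncnc2cc1O[C@@H]1CCOC1` gives 4170 nM in this assay, and compound 3 `O=C(/C=C/CN1CCCCC1)Nc1cc2c(N3CCCc4ccccc43)ncnc2cc1O[C@@H]1CCOC1` gives 3630 nM in this assay. Two steps are beyond the scatter: a 2.8-fold lower number from compound 1 to compound 2 (0.45 log units; beyond the scatter) and a 3.3-fold lower number from compound 1 to compound 3 (0.51 log units; beyond the scatter). The third, a 1.1-fold lower number from compound 2 to compound 3 (0.06 log units; within the scatter), lies within it. Compound 3 therefore holds the lowest of the three numbers, yet its gap to compound 2 is within the scatter, so the two cannot be ordered.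

Compound 4 `O=C(/C=C/CN1CCC(CO)CC1)Nc1cc2c(N3CCCc4ccccc43)ncnc2cc1O[C@@H]1CCOC1` differs from compound 3 by hydroxymethyl in place of hydrogen on a saturated ring carbon. Among the compounds with values here, none of the measured steps touches this position; all three exchange the whole amine. Within the data shown here, the only step that alters the amine itself, a 1.1-fold lower number from compound 2 to compound 3 (0.06 log units; within the scatter), stayed within the scatter. The expected step is accordingly one that stays within the scatter, a 1.0-fold lower number from compound 3 to compound 4 (0.00 log units; within the scatter), with no direction claimed. Compound 4 is estimated at 3600 nM, with a range from 1500 nM to 8500 nM.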

Compound 4, half-maximal inhibitory concentration: 5460 nM
For compound 4 the middle estimate is 1.5-fold (0.18 log units) below the measured one, within the range that was stated.
By their numbers in this assay, from the lowest: compounds 3, 2 and 4 (each within the scatter of the next); then compound 1.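

In this assay, hydroxymethyl on a saturated ring carbon, three ring bonds from the ring nitrogen, is the only change shown inside the amine ring, and it gives a 1.5-fold higher number from compound 3 to compound 4 (0.18 log units; within the scatter), so no effect of this substitution can be told from the scatter. The larger exchange of dimethylamino for 4-(hydroxymethyl)piperidin-1-yl also gives only a 1.3-fold higher number from compound 2 to compound 4 (0.12 log units; within the scatter), whereas the exchange of ethyl for the same amine gives a 2.2-fold lower number from compound 1 to compound 4 (0.33 log units; beyond the scatter), which places compound 4 with compound 2 and compound 3 rather than with compound 1. Nothing available here explains this result.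

The compounds shown leave open whether a carboxylic acid, a primary amine or a longer hydroxyalkyl chain on this ring carbon would move the number beyond the scatter from compound 3. They also leave open what an oxygen atom in place of this ring carbon would do.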